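The source may report more compounds than this note shows. Statements on the series, on what has been measured and on what is new or still open speak of the compounds shown alone.

Compound 1 `Cc1ccc(-c2nn(-c3ccc(Br)cc3)c(/N=C/N(C)C)c2C=O)cc1` gives 6000 nM in a functional assay on NPC-TW01 cells (Homo sapiens) for inhibition, read by MTT assay, with a stated time of 72 h; on this read-out lower numbers stand for stronger inhibition of growth and higher numbers for weaker inhibition of growth.
Compound 2 `CN(C)/C=N/c1c(C=O)c(-c2ccc(Cl)cc2)nn1-c1ccc(Br)cc1` reaches only the limit of this assay, reported as > 100000 nM.
Compound 3 `CN(C)/C=N/c1cc(-c2ccc(Cl)cc2)nn1-c1ccc(Br)cc1` gives 60700 nM in this assay.

Compound 2 therefore stands at the limit of this assay, and only that limit is known for it (the limit of > 100000 nM in this assay, at which 1 of the 3 values shown sits). Compound 4 `Nc1c(C=O)c(-c2ccc(Cl)cc2)nn1-c1ccc(Br)cc1` differs from compound 2 by one nitrogen atom in place of a group of 5 heavy atoms (3 carbon, 2 nitrogen; no ring), on an aromatic carbon. The two measured steps, an at least 16-fold higher number from compound 1 to compound 2 (1.22 log units; beyond the scatter) and an at least 1.6-fold lower number from compound 2 to compound 3 (0.21 log units; that floor lies within the scatter), concern chloro in place of methyl and hydrogen in place of formyl, not the group exchanged here, so neither bears directly on this step. With no comparable change measured, no shift beyond the scatter is expected, and compound 4 is expected to remain near the limit, the step of a number no higher from compound 2 to compound 4 (the limit leaves the size open) being estimated as small. Compound 4 is thus estimated at 100000 nM, between 30000 nM and 300000 nM.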

Compound 4, concentration for 50% growth inhibition: 59700 nM
The estimate for compound 4 lay 1.7-fold (0.22 log units) above the measured number, and the stated range covers the measured number.
By their numbers in this assay, from the lowest: compound 1; then compounds 4 and 3 (each within the scatter of the next). At a limit, above all of these: compound 2.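

In this assay, exchanging the group of 5 heavy atoms for amino on this aromatic carbon, next to the ring nitrogen, gives an at least 1.6-fold lower number from compound 2 to compound 4 (0.22 log units; that floor lies within the scatter). With the 4-chlorophenyl group present, the group of 5 heavy atoms is therefore not needed for a measurable number at this position. Only a floor can be read for the step, since compound 2 sits at a limit: the limit of > 100000 nM in this assay, at which 1 of the 4 values shown sits.

From the compounds shown here alone, whether amino behaves the same way alongside the methyl of compound 1 stays open. So does what an acetamide or a longer alkylamine on this carbon would give.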